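The compounds below may be only part of what the source reports. "The series", "measured", "known", "first", "only" and "open" are said of these compounds alone.

Measured compounds:
compound 1 `CCC(CC)O[C@@H]1C=C(C(=O)O)C[C@H](NC(C)=N)[C@H]1NC(C)=O`, 1840 nM
compound 2 `CCOC(=O)C1=C[C@@H](OC(CC)CC)[C@H](NC(C)=O)[C@@H](N/C(C)=N/O)C1`, 8390 nM

Both were read in an ADME assay on the whole organism (strain Sprague-Dawley) for pharmacokinetics, with Rattus norvegicus as the target, read by LC-MS, at a dose of 50 mg/kg by the oral route; on this read-out lower numbers stand for lower exposure and higher numbers for higher exposure at the dose given. Compound 2 gives 8390 nM, the higher of the two numbers; compound 1 gives 1840 nM, a gap beyond the usual scatter. For the measured compounds named here, no pair of measured compounds differs in a single place, so nothing measured yet shows the effect of changing only the group on the amine nitrogen.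

Compound 3 `CCOC(=O)C1=C[C@@H](OC(CC)CC)[C@H](NC(C)=O)[C@@H](NC(=N)N)C1` is the next to be measured. It differs from compound 2 as follows: a group of 3 heavy atoms (1 carbon, 2 nitrogen; no ring) in place of a group of 4 heavy atoms (2 carbon, 1 nitrogen, 1 oxygen; no ring), on an amine nitrogen. The exchange sits on an amine nitrogen whose other neighbours are a saturated ring carbon; the rest of compound 2 is kept.

Without a measured step of this kind, the expectation rests on compound 2 alone. The number for compound 3 is expected to come out lower than that of compound 2, by a step of a 3.4-fold lower number from compound 2 to compound 3 (0.53 log units; beyond the scatter) that should exceed the scatter though its size is uncertain. Compound 3 is estimated at 2500 nM, with a range from 700 nM to 8000 nM.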

Compound 3, maximal plasma concentration: 282 nM
Beside the measured number, compound 3's estimate is 8.9-fold (0.95 log units) above it, outside the stated range (below it).
By their numbers in this assay, from the lowest: compound 3; then compound 1; then compound 2.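

In this assay, for the compounds shown here, the first single-place step at this site is large: the group of 3 heavy atoms (1 carbon, 2 nitrogen; no ring) in place of the group of 4 heavy atoms (2 carbon, 1 nitrogen, 1 oxygen; no ring), on an amine nitrogen whose other neighbours are a saturated ring carbon, gives a 30-fold lower number from compound 2 to compound 3 (1.47 log units; beyond the scatter). Maximal plasma concentration at this oral dose is thus strongly sensitive to this one exchange, with the rest of compound 2 kept, which the earlier compounds, differing in more than one place, could not show. Nothing available bears on the reason for the drop.

Open, going by these compounds, is how a plain amine on this nitrogen would compare with these two groups. Also open, on these data alone, is whether the exchange gives a step of similar size with a carboxylic acid in place of the ethyl ester.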